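This account rests on a few compounds, and the source may have more. Where it says the series, first, only, none or still open, it means among the compounds named here.

Measured so far in an assay on CHO cells for displacement of a labelled ligand from muscarinic acetylcholine receptor M5 (Homo sapiens), read by scintillation counting, with a stated time of 2 h; on this read-out higher numbers stand for weaker inhibition and lower numbers for stronger inhibition:
compound 1, `COc1ccc(COC(=O)N(c2ccccc2)C2CN3CCC2CC3)cc1F`, gives 40 nM;
compound 2, `O=C(OCCCc1ccccc1)N(c1ccccc1)C1CN2CCC1CC2`, gives 260 nM;
compound 3, `O=C(OCc1ccc(Cl)c(Cl)c1)N(c1ccccc1)C1CN2CCC1CC2`, gives 60 nM.

Compound 3 holds the second highest of the three numbers in this assay. Its nearest neighbour is compound 1, a difference that stays within the scatter (a 1.5-fold higher number from compound 1 to compound 3 (0.18 log units; within the scatter)); its furthest is compound 2, a modest gap beyond the scatter (a 4.3-fold lower number from compound 2 to compound 3 (0.64 log units; beyond the scatter)). Compound 4, `COc1ccc(COC(=O)N(c2ccccc2)C2CN3CCC2CC3)cc1`, differs from compound 3 in one place: 4-methoxyphenyl in place of 3,4-dichlorophenyl on a saturated chain carbon bound to an oxygen next to a carbonyl group. Among the compounds with values here, of the measured steps, the one from compound 1 to compound 3 bears most directly on this change, because a 1.5-fold higher number from compound 1 to compound 3 (0.18 log units; within the scatter) compares two aryl variants at the same place and lands within the scatter. Within the data shown here, the only step beyond the scatter, a 4.3-fold lower number from compound 2 to compound 3 (0.64 log units; beyond the scatter), concerns phenethyl, which plays no part here. Compound 4 is therefore expected to sit close to compound 3, with an estimated step of a 1.2-fold lower number from compound 3 to compound 4 (0.08 log units; within the scatter) that stays within the scatter. Compound 4 is estimated at 50 nM, expected between 20 nM and 130 nM.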

Compound 4, inhibition constant: 470 nM
Beside the measured number, compound 4's estimate is 9.4-fold (0.97 log units) below it; measured number outside the range, above it.
By their numbers in this assay, from the lowest: compounds 1 and 3 (each within the scatter of the next); then compounds 2 and 4 (each within the scatter of the next).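

In this assay, 4-methoxyphenyl in place of 3,4-dichlorophenyl gives a 7.8-fold higher number from compound 3 to compound 4 (0.89 log units; beyond the scatter) and so shows that this place does not tolerate every aryl group alike, which the earlier aryl pair could not reveal. Hydrogen in place of fluoro on an aromatic carbon gives a 12-fold higher number from compound 1 to compound 4 (1.07 log units; beyond the scatter) and is the largest of the new steps, so the match between 3-fluoro-4-methoxyphenyl and 3,4-dichlorophenyl does not carry over to 4-methoxyphenyl. 4-Methoxyphenyl in place of phenethyl gives a 1.8-fold higher number from compound 2 to compound 4 (0.26 log units; within the scatter) and leaves compound 4 grouped with compound 2 on this read-out.

Nothing in the data given accounts for the size of these steps. Still open, going by these compounds, is whether a methyl group in place of that fluoro, with the methoxy kept, or a 4-chlorophenyl group would give numbers nearer those of compound 1 and compound 3.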